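The source may hold more compounds than are shown below. What is called first, only, known or untested is meant among the compounds shown, and "the series" means these compounds.

Compound 1 `CCCCCCCCN1C(=O)CCc2cc(-n3cnnc3)ccc21` gives 300 mg/kg in a functional assay on the whole organism (strain KunMing) with Mus musculus as the target, in the maximal electroshock model, with a stated time of 4 h; on this read-out lower numbers stand for an effect already at smaller amounts and higher numbers for an effect only at larger amounts of compound.
Compound 2 `CCCCCCN1C(=O)CCc2cc(-n3cnnc3)ccc21` gives 300 mg/kg in this assay.
Compound 3 `O=C1CCc2cc(-n3cnnc3)ccc2N1Cc1ccc(F)cc1` gives 300 mg/kg in this assay.

Three compounds share one core and differ only in the group on the saturated chain carbon bound to the amide-type nitrogen in the ring. Compound 3 stands level with compound 1 and compound 2 at the digits shown: the step of no change at the digits printed from compound 1 to compound 3 (within the scatter) and the step of no change at the digits printed from compound 2 to compound 3 (within the scatter) both lie within the scatter, as does the step of no change at the digits printed from compound 1 to compound 2 (within the scatter) between the two chain-bearing compounds.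

Compound 4 `O=C1CCc2cc(-n3cnnc3)ccc2N1Cc1cccc(Cl)c1` is the next member. Its change from compound 3 is 3-chlorophenyl in place of 4-fluorophenyl on a saturated chain carbon bound to an amide-type nitrogen in a ring.

Going by the values given here, no measured step swaps one halogen-bearing aryl group for another, so the bearing evidence is indirect. The steps of no change at the digits printed from compound 1 to compound 3 (within the scatter) and no change at the digits printed from compound 2 to compound 3 (within the scatter) show that even the exchange of a long chain for the aryl group left this assay unchanged. Compound 4 is therefore expected to show no step beyond the scatter, no change at the digits printed from compound 3 to compound 4 (within the scatter). Compound 4 is estimated at 300 mg/kg, within 150 mg/kg to 600 mg/kg.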

Compound 4, minimum effective dose: 300 mg/kg
Beside the measured number, compound 4's estimate shows no gap at the digits printed; low and high end bracket the measured number.
By their numbers in this assay, from the lowest: compounds 1, 2, 3 and 4 (each within the scatter of the next).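

Swapping 4-fluorophenyl for 3-chlorophenyl on a saturated chain carbon bound to an amide-type nitrogen in a ring is the first direct exchange of one halogen-bearing aryl group for another here, and in this assay it gives no change at the digits printed from compound 3 to compound 4 (within the scatter). The 3-chlorophenyl group also stands level with both chains, with no change at the digits printed from compound 2 to compound 4 (within the scatter) on exchange for pentyl and no change at the digits printed from compound 1 to compound 4 (within the scatter) on exchange for heptyl, so neither the halogen, its ring position nor the chain-to-aryl exchange separates these compounds at the digits shown. No supporting evidence bears on this result.

As far as these compounds go, whether a terminal amine or carboxylic acid on the chain, or a methoxy group on the benzyl ring, would shift the value in this assay remains open. Also open, from the compounds shown here alone, is whether any change to the shared core would do so.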